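The compounds below may be only part of what the source reports. "The series", "measured", "known", "first", "only" and "open" are said of these compounds alone.

Three compounds have been measured in a functional assay on BJAB cells (Homo sapiens) for antiproliferative activity, with a stated time of 4 days; a higher number here means that more compound is needed for the effect, a lower number that less compound is needed:

Compound 1 `CCSc1sc(-n2nc(C)c(Cc3ccccc3[N+](=O)[O-])c2C(=O)O)nc1-c1ccc(Cl)c(Cl)c1` gives 59000 nM.
Compound 2 `CC(=O)Nc1ccc(-c2c(C)nn(-c3nc(-c4ccc(Cl)c(Cl)c4)c(SC(C)C)s3)c2C(=O)O)cc1` gives 139000 nM.
Compound 3 `COC(=O)c1c(Cc2ccccc2[N+](=O)[O-])c(C)nn1-c1nc(-c2ccc(Cl)c(Cl)c2)c(SC(C)C)s1` gives 93000 nM.

Compound 2 stands at the highest number of the three. Its number and that of compound 3 lie within the scatter of each other, so these two cannot be told apart. The gap from compound 1 to compound 2 lies beyond the scatter, so compound 2 needs more compound than compound 1 for the same effect. For the measured compounds named here, no pair of measured compounds differs in one place only, so no single step has been measured, and nothing among the three shows how a change at this position moves the number.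

Compound 4 `Cc1nn(-c2nc(-c3ccc(Cl)c(Cl)c3)c(SC(C)C)s2)c(C(=O)O)c1-c1cccnc1` has not yet been measured in this assay. It differs from compound 2 in one place: pyridin-3-yl in place of 4-acetamidophenyl on an aromatic carbon. Going by the values given here, with no measured step of this kind to rest on, and with all three measured numbers lying in a narrow band, the expected step is a 1.4-fold lower number from compound 2 to compound 4 (0.14 log units; within the scatter), which is taken to stay within the scatter. Compound 4 is estimated at 100000 nM, between 35000 nM and 300000 nM.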

Compound 4, half-maximal effective concentration: 12000 nM
Compound 4: the middle estimate sits 8.3-fold (0.92 log units) above what was measured, outside the stated range (below it).
By their numbers in this assay, from the lowest: compound 4; then compounds 1, 3 and 2 (each within the scatter of the next, the first and the last beyond it).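

Putting pyridin-3-yl in place of 4-acetamidophenyl on this aromatic carbon of the five-membered ring gives, in this assay, a 12-fold lower number from compound 2 to compound 4 (1.06 log units; beyond the scatter). For the compounds shown here, this is the first single change measured, and it shows that the group at this position can move the number well beyond the scatter, which the three earlier compounds, differing from each other in more than one place, could not show. Nothing available explains the size of this step.

The step changes the ring and removes the acetamido group at once, so it does not show which of the two matters for the number. Going by these compounds, a plain phenyl or a pyridin-4-yl at this carbon would separate these two parts of the change, and how far the step carries over to the other groups on the shared core remains open.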